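The source may report more compounds than this note shows. Statements on the series, on what has been measured and on what is new or still open speak of the compounds shown alone.

In an ADME assay on ECV-304 cells (Homo sapiens) for cytotoxicity, read by MTT assay, with a stated time of 72 h (a higher number here means a weaker inhibitor, a lower number a stronger inhibitor), compound 1 `COc1ccc(C2=C(c3cc(OC)c(OC)c(OC)c3)C(=O)CC2O[SiH2]C(C)(C)C)cc1` reads > 100 ug/mL as a limit of the assay and not a number. Among the compounds with values here, compound 2 `COc1ccc(OC)c(C2=C(c3cc(OC)c(OC)c(OC)c3)C(=O)CC2O[SiH2]C(C)(C)C)c1` gives 6.5 ug/mL in this assay and so holds the only actual number so far. Within the data shown here, the one measured step is an at least 15-fold lower number from compound 1 to compound 2 (1.18 log units; beyond the scatter) and lies beyond the scatter, but it sits on a double-bonded ring carbon and not at the oxygen that changes next. Compound 3 `COc1ccc(OC)c(C2=C(c3cc(OC)c(OC)c(OC)c3)C(=O)CC2O)c1` differs from compound 2 by a hydrogen atom in place of a group of 5 heavy atoms (4 carbon, 1 silicon; no ring), on an oxygen on a saturated carbon and keeps the rest of the structure. Among the measured compounds shown here, no measured step covers this place, so the size of the earlier step serves only as a warning that numbers can move widely. The expected step is a 1.5-fold higher number from compound 2 to compound 3 (0.19 log units; within the scatter) and the central expectation is no shift beyond the scatter, with either direction remaining open. For compound 3 the estimated value is 10 ug/mL with an expected range from 1.5 ug/mL to 60 ug/mL in this series.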

Compound 3, half-maximal inhibitory concentration: > 100 ug/mL
Compound 3: a limit, no number (the forecaster's own chance of this, stated with the estimate: 15%); middle value at least 10-fold (1.00 log units) away from the limit.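

At the oxygen on a saturated carbon, the change is not neutral in this assay: a hydrogen atom in place of the group of 5 heavy atoms (4 carbon, 1 silicon; no ring) gives an at least 15-fold higher number from compound 2 to compound 3 (1.18 log units; beyond the scatter). Compound 2 now has a step beyond the scatter at each of the two places changed, so its number depends on both the 2,5-dimethoxyphenyl group and the group on this oxygen. Both steps are open-ended, with their full size unknown: the limit of > 100 ug/mL in this assay, at which 2 of the 3 values shown sit.

The compounds shown cannot tell whether silicon is needed or whether a carbon-only group on this oxygen, such as methyl or benzyl, would keep a measurable number. From the compounds shown here alone, how an acetate ester or an amine at this place would read also stays open.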